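Carbamate Replaces the Amide-Linked Chain on the Shared Core

A few compounds are considered here, and "the series" means these few. Any claim that something is new, unique, unknown or untested is made for them only; others in the source may bear on it.

In a functional assay on PANC-1 cells (Homo sapiens) for inhibition, read by MTT assay, with a stated time of 24 h, tested at 10 uM (on this read-out lower numbers stand for less inhibition and higher numbers for more inhibition at the one concentration tested (going by the name of the read-out)), compound 3 `CC(C)=CCC1Cc2c(OCCCNC(=O)c3ccco3)cc(=O)n(CCCO)c2CC1(C)C` gives 4.3%, the second highest of three numbers: nearest to it stands compound 2 `COc1ccc(C(=O)NCCCOc2cc(=O)n(CCCO)c3c2CC(CC=C(C)C)C(C)(C)C3)cc1`, which gives 2.5%, and furthest compound 1 `CC(C)=CCC1Cc2c(OCc3ccccc3)cc(=O)n(CCCO)c2CC1(C)C`, which gives 11.1%. Compound 4 `COc1ccccc1NC(=O)Oc1cc(=O)n(CCCO)c2c1CC(CC=C(C)C)C(C)(C)C2` differs from compound 3 by (2-methoxyphenyl)carbamoyl in place of 3-(((furan-2-yl)carbonyl)amino)propyl on an oxygen on an aromatic ring. Both measured steps change what hangs from that same oxygen or within that group: a number 6.8 percentage points lower from compound 1 to compound 3 (within the scatter) and a number 1.8 percentage points higher from compound 2 to compound 3 (within the scatter). Neither moved beyond the scatter, so for the step from compound 3 to compound 4 no change beyond the scatter is expected, a number 1.7 percentage points higher from compound 3 to compound 4 (within the scatter). Compound 4 is therefore estimated to give about 6%, with a range from 0% to 15%.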

Compound 4, a percentage reported as inhibition, at one concentration (the size of the read-out at that concentration, not a potency): 0%
Estimate against measurement, compound 4: 6 percentage points above; the measured number falls inside the stated range.
By their numbers in this assay, from the lowest: compounds 4, 2, 3 and 1 (each within the scatter of the next, the first and the last beyond it).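

At the oxygen on the aromatic ring, this assay now shows its first step beyond the scatter: a number 11.1 percentage points lower from compound 1 to compound 4 (beyond the scatter), with (2-methoxyphenyl)carbamoyl in place of benzyl. The step with the same group replacing 3-(((furan-2-yl)carbonyl)amino)propyl, a number 4.3 percentage points lower from compound 3 to compound 4 (within the scatter), stays within it, so only the exchange for benzyl registers. Nothing available explains either step.

The compounds shown leave open whether an amine or a carboxylic acid on this oxygen would give a number above that of compound 1.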